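The source may report more compounds than this note shows. Statements on the series, on what has been measured and on what is new or still open speak of the compounds shown alone.

Measured so far in a functional assay on HCT-116 cells (Homo sapiens) for cytotoxicity, read by MTT assay, with a stated time of 48 h; on this read-out higher numbers stand for weaker inhibition and lower numbers for stronger inhibition:
- compound 1 `O=C(/C=C/c1ccc2c(c1)B(O)OC2)c1ccc(-c2ccccc2)cc1`: 9500 nM
- compound 2 `O=C(/C=C/c1ccc2c(c1)B(O)OC2)c1ccco1`: 24100 nM
- compound 3 `O=C(/C=C/c1ccc2c(c1)B(O)OC2)c1ccc(F)cc1`: 2800 nM

Compound 3 gives the lowest number of the three, and both gaps lie beyond the scatter: a 3.4-fold lower number from compound 1 to compound 3 (0.53 log units; beyond the scatter) and an 8.6-fold lower number from compound 2 to compound 3 (0.93 log units; beyond the scatter). Compound 4 `O=C(/C=C/c1ccc2c(c1)B(O)OC2)c1ccc(I)cc1` differs from compound 3 by iodo in place of fluoro on an aromatic carbon. Within the data shown here, no measured step exchanges one halogen for another. The step from compound 1 to compound 3 is the only one on this aromatic carbon and shows that what sits there moves the number; the step from compound 2 to compound 3 concerns the group on the carbonyl carbon and bears only loosely on the change. A small step in this assay, not clearly beyond the scatter and of uncertain direction, is therefore expected. Compound 4 is estimated at 3500 nM, with a range of 1200 nM to 10000 nM, which amounts to an expected 1.3-fold higher number from compound 3 to compound 4 (0.10 log units; within the scatter).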

Compound 4, half-maximal inhibitory concentration: 11600 nM
Estimate against measurement, compound 4: 3.3-fold (0.52 log units) below; measured number above the stated range.
By their numbers in this assay, from the lowest: compound 3; then compounds 1 and 4 (each within the scatter of the next); then compound 2.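

Halogen identity on this aromatic carbon moves the number in this assay (a 4.1-fold higher number from compound 3 to compound 4 (0.62 log units; beyond the scatter)), so iodo cannot stand in for fluoro here. Iodo and phenyl on this carbon are not told apart (a 1.2-fold higher number from compound 1 to compound 4 (0.09 log units; within the scatter)), while the 4-iodophenyl group still holds an advantage over furan-2-yl on the carbonyl carbon (a 2.1-fold lower number from compound 2 to compound 4 (0.32 log units; beyond the scatter)). Nothing on hand explains the difference between fluoro and iodo.

As far as these compounds go, whether chloro or bromo on this carbon would read closer to fluoro or to iodo stays open. Equally open, from the compounds shown here alone, is how an amine or a carboxylic acid there would read.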